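Ester chain length and cytotoxicity in three analogues

This account rests on a few compounds, and the source may have more. Where it says the series, first, only, none or still open, it means among the compounds named here.

In a functional assay on A549 cells (Homo sapiens) for cytotoxicity, read by MTT assay, with a stated time of 24 h, tested at 80 uM (a lower number here means a stronger effect, a higher number a weaker effect of the compound at the concentration tested), compound 1 `CCCCCCCCCCCCOC(=O)CCC(=O)N1CCN(CCCOc2cc3c(Nc4ccc(F)c(Cl)c4)ncnc3cc2OC)CC1` gives 2.3%.
In this assay compound 2 `CCCCCCCCCCCCCCCCOC(=O)CCC(=O)N1CCN(CCCOc2cc3c(Nc4ccc(F)c(Cl)c4)ncnc3cc2OC)CC1` gives 74.3%.

Going by the values given here, compound 2 stands highest of the two numbers measured, and the only step known is a number 72 percentage points higher from compound 1 to compound 2 (beyond the scatter), a large change beyond the scatter, from butyl in place of hydrogen on a saturated chain carbon, ten or more bonds along the chain from an oxygen next to a carbonyl group.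

Compound 3 `CCCCCCCCCCCCCCCCCCCOC(=O)CCC(=O)N1CCN(CCCOc2cc3c(Nc4ccc(F)c(Cl)c4)ncnc3cc2OC)CC1` differs from compound 2 by propyl in place of hydrogen on a saturated chain carbon, ten or more bonds along the chain from an oxygen next to a carbonyl group. Among the compounds with values here, this is the same kind of change, at the same place, as the one measured step, and that step was large, so a further rise is expected from the longer chain in compound 3. Compound 2 already sits close to the upper end of the scale in this assay, so the room left for a rise is limited, and the expected step to compound 3 is a number 10.7 percentage points higher from compound 2 to compound 3 (beyond the scatter), smaller than the measured one. Within the data shown here, with only one step to rest on, the estimate for compound 3 is 85%, with an expected range from 60% to 100%.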

Compound 3, a percentage reported as activity, at one concentration (the size of the read-out at that concentration, not a potency): 88.4%
For compound 3 the middle estimate is 3.4 percentage points below the measured one; the range from low to high includes it.
By their numbers in this assay, from the lowest: compound 1; then compound 2; then compound 3.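

In this assay, a further lengthening at the same place, propyl in place of hydrogen on a saturated chain carbon, ten or more bonds along the chain from an oxygen next to a carbonyl group, keeps the same direction and gives a number 14.1 percentage points higher from compound 2 to compound 3 (beyond the scatter), a modest step, whereas the earlier one, a number 72 percentage points higher from compound 1 to compound 2 (beyond the scatter), was large. Taken end to end, the chain change gives a number 86.1 percentage points higher from compound 1 to compound 3 (beyond the scatter), so among these three compounds the number rises with each lengthening of the ester chain, and none goes against this; the effect at the concentration tested therefore weakens along the series. No measurement at hand bears on what lies behind this trend.

The compounds shown leave open whether a shorter chain than the one in compound 1 would keep the strong effect or lose it, so the low end of the trend remains undefined. They also leave open whether the chain length alone governs the read-out, or whether a branched chain, or a chain ending in an amine or a carboxylic acid, would change it at this position.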